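The source may hold more compounds than are shown below. What is called first, only, known or untested is meant among the compounds shown, and "the series" means these compounds.

Measured compounds and their values:

Compound 1, `CCCNC(=C\C(=O)/C=C/c1ccc(O)c(OC)c1)/C=C/c1ccc(O)c(OC)c1`, gives 88%.
Compound 2, `COc1cc(/C=C/C(=O)CC(=O)/C=C/c2ccc(OC(C)=O)c(OC)c2)ccc1OC(C)=O`, gives 90%.
Compound 3, `CC(=O)Oc1ccc(/C=C/C(=O)/C=C(/C=C/c2ccc(OC(C)=O)cc2)NCC(C)C)cc1`, gives 85%.

These three compounds were tested in a functional assay on Caco-2 cells (Homo sapiens), read by fluorescence, tested at 10 uM; a lower number here means a stronger effect, a higher number a weaker effect of the compound at the concentration tested. All three read close together: compound 1 sits second highest of the three numbers, with compound 2 nearest, a little higher, and compound 3 furthest, a little lower, but both gaps lie within the usual scatter of such measurements, so no order among them can be claimed. In plain terms, every compound shown has only a weak effect at the concentration tested.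

The next compound, compound 4, `COc1cc(/C=C/C(=O)/C=C(/C=C/c2ccc(O)c(OC)c2)NCC(C)C)ccc1O`, has not yet been measured in this assay. It differs from compound 1 in a single place: methyl in place of hydrogen on a saturated chain carbon bound to two saturated chain carbons. Put another way, the propylamino group of compound 1 becomes an isobutylamino group in compound 4; the rest of the two structures is the same.

For the measured compounds named here, no pair of measured compounds differs in only one place, so there is no measured step to lean on. Given how tightly compound 1, compound 2 and compound 3 cluster, the expected step in this assay from compound 1 to compound 4 is a number 1 percentage points lower from compound 1 to compound 4 (within the scatter), that is, no change beyond the scatter. Compound 4 is therefore estimated at 87%, with a likely range from 78% to 96%.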

Compound 4, a percentage reported as activity, at one concentration (the size of the read-out at that concentration, not a potency): 74%
Beside the measured number, compound 4's estimate is 13 percentage points above it, outside the stated range (below it).
By their numbers in this assay, from the lowest: compound 4; then compounds 3, 1 and 2 (each within the scatter of the next).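

Going from the propylamino group to the isobutylamino group gives a number 14 percentage points lower from compound 1 to compound 4 (beyond the scatter) in this assay, the first single change in this set whose size can be read, since the earlier compounds offered no such pair. It shows that this saturated chain carbon bound to two saturated chain carbons is not a silent position: one added methyl, a single heavy atom with no hydrogen-bond donors or acceptors, is enough to shift the read-out modestly towards a stronger effect, while all else in the structure stays the same. Nothing measured here explains why this small branch has that effect, so the step stands as an observation without a known cause.

What the compounds shown leave open is whether the trend continues with more branching, as in a tert-butylamino or neopentylamino group, or whether a longer chain such as pentylamino or a ring such as cyclopropylmethylamino would do as well or better. On these data alone, it also remains open whether the same methyl would bring a similar step on another core, since this is a single pair read at one concentration.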